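Amide for Acid on a Uridine Diphosphate Agonist Scaffold

A few compounds are considered here, and "the series" means these few. Any claim that something is new, unique, unknown or untested is made for them only; others in the source may bear on it.

Compound 1 `O=C(O)CSc1ccn([C@@H]2O[C@H](COP(=O)(O)OP(=O)(O)O)[C@@H](O)[C@H]2O)c(=O)n1` is one of three uridine diphosphate analogues examined in an in vitro functional assay on 1321-N1 cells for agonist activity at P2Y purinoceptor 6 (Homo sapiens); on this read-out lower numbers stand for an effect already at smaller amounts and higher numbers for an effect only at larger amounts of compound. There compound 1 gives 1700 nM, the lowest of the three numbers. Compound 2 `O=c1ccn([C@@H]2O[C@H](COP(=O)(O)OP(=O)(O)O)C[C@H]2O)c(=O)[nH]1` gives 2500 nM, a difference that lies within the usual scatter, whereas compound 3 `N[C@@H]1[C@H](O)[C@@H](COP(=O)(O)OP(=O)(O)O)O[C@H]1n1ccc(=O)[nH]c1=O` gives 3900 nM, a gap that is beyond it. Compound 4 `NC(=O)CSc1ccn([C@@H]2O[C@H](COP(=O)(O)OP(=O)(O)O)[C@@H](O)[C@H]2O)c(=O)n1` has not yet been measured; it differs from compound 1 by amino in place of hydroxy on a carbonyl carbon. For the measured compounds named here, no measured pair shows how this change behaves, so the expectation is for little movement, perhaps a slight drift toward weaker action. The estimate for compound 4 is 2500 nM, expected to fall between 900 nM and 7000 nM, a step of a 1.5-fold higher number from compound 1 to compound 4 (0.17 log units; within the scatter).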

Compound 4, half-maximal effective concentration: 18000 nM
Compound 4: middle estimate off by 7.2-fold (0.86 log units), on the low side, outside the stated range (above it).
By their numbers in this assay, from the lowest: compounds 1, 2 and 3 (each within the scatter of the next, the first and the last beyond it); then compound 4.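

Amino in place of hydroxy on a carbonyl carbon, which turns carboxy into carbamoyl, gives the first readable result for this position: in this assay it brings an 11-fold higher number from compound 1 to compound 4 (1.02 log units; beyond the scatter). The exchange keeps the heavy-atom and hydrogen-bond donor counts the same, yet the step lies well beyond the scatter, so this position does not tolerate the change unnoticed. Nothing at hand explains the step. From the compounds shown here alone, whether a methyl ester on that carbonyl carbon, or a longer chain in place of carboxymethyl, would stay near compound 1 or fall with compound 4 remains open.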